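The compounds below may be only part of what the source reports. "The series", "measured", "known", "first", "only" and "open" are said of these compounds alone.

In a functional assay on MCF7 cells (Homo sapiens) for antiproliferative activity, read by MTT assay, with a stated time of 72 h (a lower number here means a stronger inhibitor, a higher number a weaker inhibitor), three compounds have been measured:

compound 1 `CCCCCCCCCCNC[C@@H]1OC[C@H](N)[C@@H]1O`: 34200 nM
compound 2 `CCCCCCCCNC[C@@H]1OC[C@H](N)[C@@H]1O`: 96600 nM
compound 3 `CCCCCCCNC[C@@H]1OC[C@H](N)[C@H]1O`: > 128000 nM, a limit of the assay

Among the compounds with values here, of the two true numbers, compound 2 has the higher, and the one measured step is a 2.8-fold higher number from compound 1 to compound 2 (0.45 log units; beyond the scatter). The data also include (the limit of > 128000 nM in this assay, at which 1 of the 3 values shown sits). Compound 4 `CCCCCCCCNC[C@@H]1OC[C@H](N)[C@H]1O` departs from compound 2 only in configuration: the two compounds have the same atoms and bonds and differ only in configuration as drawn: 1 of 3 stereo elements differ; a stereocentre at a saturated ring carbon is drawn S in compound 2 and R in compound 4. The measured step alters the chain and not a stereocentre, so it gauges scale only. Within the data shown here, no measured step isolates configuration, so in this assay a modest move to a higher number is expected, possibly none beyond the scatter, and a report as a limit is plausible. The expected step is a 1.1-fold higher number from compound 2 to compound 4 (0.06 log units; within the scatter). For compound 4 the estimate is 110000 nM, within an expected range of 50000 nM to 250000 nM.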

Compound 4, half-maximal inhibitory concentration: > 128000 nM
Compound 4 ended at the assay's limit (the forecaster's own chance of this, stated with the estimate: 45%); at least 1.1-fold (0.06 log units) between middle value and limit.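

In this assay, within the data shown here, changing one stereocentre at a saturated ring carbon from S to R, with atoms and bonds untouched, gives an at least 1.3-fold higher number from compound 2 to compound 4 (0.12 log units; that floor lies within the scatter), the first step to isolate configuration, though its floor alone does not show an effect. Compound 4 gives > 128000 nM, a limit of the assay, and the step linking it to compound 3 cannot be read. Configuration is the only difference in this pair: the fact that compounds 2 and 4 differ only in the configuration as drawn

Going by these compounds, whether the longer chain of compound 1 would bring the R form back to a readable number stays open. So does the effect of the other two stereo elements, or of a carboxylic acid on the shared core.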